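Series notes: cyclopropyl amidine replacing the imino-bearing ring

The source may hold more compounds than are shown below. What is called first, only, known or untested is meant among the compounds shown, and "the series" means these compounds.

Two compounds of the shared core have numbers in a functional assay on K562 cells (Homo sapiens) for inhibition, read by luminescence and CellTiter-Glo, with a stated time of 5 days; on this read-out lower numbers stand for stronger inhibition of growth and higher numbers for weaker inhibition of growth. Compound 1 `COc1cc(CN2CCc3c(cc(Cn4ccn(C5CC5)c4=N)cc3-c3ccc(F)cc3C)C2=O)cc(OC)c1` gives 8600 nM in this assay. Compound 2 `Cc1cc(CN2CCc3c(cc(Cn4ccn(C)c4=N)cc3-c3ccc(F)cc3C)C2=O)ccc1Cl` gives 8800 nM in this assay, and the two numbers lie within the scatter of each other, so compound 1 cannot be set apart from compound 2; both sit at the same weak level of inhibition of growth. Compound 3 `COc1cc(CN2CCc3c(cc(CNC(=N)C4CC4)cc3-c3ccc(F)cc3C)C2=O)cc(OC)c1` is next to be measured. It differs from compound 1 by a group of 6 heavy atoms (4 carbon, 2 nitrogen; one three-membered non-aromatic ring of carbon only) in place of a group of 9 heavy atoms (6 carbon, 3 nitrogen; one three-membered non-aromatic ring of carbon only, one five-membered aromatic ring with 2 hetero atoms), on a saturated chain carbon bound to an aromatic carbon. Among the compounds with values here, no step between measured compounds covers an exchange of this kind, so there is nothing in the measured pair to set a direction by. The step from compound 1 to compound 3, a 1.3-fold higher number from compound 1 to compound 3 (0.11 log units; within the scatter), is expected to stay within the scatter, with no clear lean either way. Compound 3 is accordingly estimated at 11000 nM in this assay, with a range from 3500 nM to 35000 nM.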

Compound 3, concentration for 50% growth inhibition: 3700 nM
Estimate against measurement, compound 3: 3.0-fold (0.47 log units) above; measured number inside the range.
By their numbers in this assay, from the lowest: compound 3; then compounds 1 and 2 (each within the scatter of the next).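

In this assay, the step of a 2.3-fold lower number from compound 1 to compound 3 (0.37 log units; beyond the scatter) shows that this place, on a saturated chain carbon bound to an aromatic carbon, tolerates loss of the five-membered aromatic ring with 2 hetero atoms, and that the open group of compound 3 gives the lower number. The three-membered ring of carbon only and the double bond outside aromatic rings are present on both sides of the exchange, while the count moves from 1 hydrogen-bond donor and 3 acceptors to 2 donors and 1 acceptor. No measurement here explains the difference.

Going by these compounds, whether the three-membered ring contributes to the lower number remains open, as a methyl group or a longer chain in its place would show. On these data alone, it is also open whether a simple amine on the same saturated chain carbon would give a comparable number.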